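This account rests on a few compounds, and the source may have more. Where it says the series, first, only, none or still open, it means among the compounds named here.

Measured compounds:
compound 1 `Cc1ccc(S(=O)(=O)Oc2ccc3c(c2C)[C@H](Cn2cc(-c4ccc(Br)cc4)nn2)[C@@]24CC(=O)[C@@](C)(CC[C@@H]32)C4)cc1`: > 20000 nM
compound 2 `Cc1c(O)ccc2c1[C@H](Cn1cc(-c3ccccn3)nn1)[C@@]13CC(=O)[C@@](C)(CC[C@@H]21)C3`: > 20000 nM

Both compounds were tested in a functional assay on SMMC-7721 cells (Homo sapiens) for cytotoxicity, read by MTT assay, with a stated time of 4 days; on this read-out higher numbers stand for weaker inhibition and lower numbers for stronger inhibition. Compound 1 gives > 20000 nM, which is a limit of the assay and not a number. Compound 2 likewise gives > 20000 nM, also a limit rather than a number. For the measured compounds named here, compound 1 therefore cannot be placed on a scale of potency: it stands at the limit of > 20000 nM in this assay, at which 2 of the 2 values shown sit, and the one other value shown is the same limit. Going by the values given here, no pair of measured compounds differs in a single place, so no measured step is available to lean on.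

Compound 3 `COc1ccc(-c2cn(C[C@H]3c4c(ccc(OS(=O)(=O)c5ccc(C)cc5)c4C)[C@@H]4CC[C@@]5(C)C[C@]43CC5=O)nn2)cc1` differs from compound 1 in one place, (methoxy in place of bromo on an aromatic carbon). With both shown values at the limit, this change has no measured counterpart here, and the expectation rests on compound 1 standing at the limit of > 20000 nM in this assay, at which 2 of the 2 values shown sit. Compound 3 is therefore expected to remain at or around the limit, with an estimated 20000 nM and a range from 5000 nM to 80000 nM. The step this estimate means, a number no higher from compound 1 to compound 3 (the limit leaves the size open), is expected to be none beyond the scatter.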

Compound 3, half-maximal inhibitory concentration: > 20000 nM
Compound 3: no number, only a limit; the forecaster's own chance of this, stated with the estimate: 75%; the middle value lies on the limit itself.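

In this assay compound 3 gives > 20000 nM, which is a limit of the assay and not a number. For the compounds shown here, compound 1 also stands at a limit, so no step between compound 1 and compound 3 can be read. The compounds shown leave open what change on the shared core would bring a measurable value in this assay, as all of them share one limit: the limit of > 20000 nM in this assay, at which 3 of the 3 values shown sit.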